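Benzyl in place of trifluoromethylphenyl on the ring nitrogen

The source may report more compounds than this note shows. Statements on the series, on what has been measured and on what is new or still open speak of the compounds shown alone.

Of the compounds shown here, three built on one shared core have been tested in an ADME assay on Huh-7 cells (Homo sapiens) for cytotoxicity; on this read-out lower numbers stand for higher toxicity in this test and higher numbers for lower toxicity in this test. Compound 1 `Cc1ccccc1-c1nn(-c2ccccc2Cl)cc1CNCCN1CCN(C)CC1` gives > 20000 nM in this assay, which is the limit of > 20000 nM in this assay, at which 1 of the 3 values shown sits, rather than a measured number. Compound 2 `Cc1ccccc1-c1nn(-c2ccc(C(F)(F)F)cc2)cc1CNCCN1CCN(C)CC1` gives 11000 nM in this assay. Compound 3 `Cc1ccccc1-c1nn(-c2cccc(C(F)(F)F)c2)cc1CNCCN1CCN(C)CC1` gives 18000 nM in this assay. The steps between them are an at least 1.8-fold lower number from compound 1 to compound 2 (0.25 log units; that floor lies within the scatter), an at least 1.1-fold lower number from compound 1 to compound 3 (0.04 log units; that floor lies within the scatter) and a 1.6-fold higher number from compound 2 to compound 3 (0.21 log units; within the scatter); compound 3 thus stands close to compound 2, while compound 1 is known only as a limit. All three differ solely in the group on the same aromatic nitrogen, and compound 4 `Cc1ccccc1-c1nn(Cc2ccccc2)cc1CNCCN1CCN(C)CC1` changes that place once more: benzyl in place of 3-(trifluoromethyl)phenyl on an aromatic nitrogen. The measured swaps at this position each stayed within the scatter, and the same is expected here, with an estimated 1.2-fold lower number from compound 3 to compound 4 (0.08 log units; within the scatter). Compound 4 is therefore expected to give about 15000 nM, with a likely range from 5000 nM to 40000 nM.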

Compound 4, half-maximal cytotoxic concentration: > 20000 nM
Compound 4 gave a limit, no number; the forecaster's own chance of this, stated with the estimate: 30%; at least 1.3-fold (0.12 log units) between middle value and limit.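

Compound 4 gives a limit and not a number, and compound 1 does the same: the limit of > 20000 nM in this assay, at which 2 of the 4 values shown sit. On this assay, the position thus also accepts benzyl, a group with no fluorine, and the steps read an at least 1.1-fold higher number from compound 3 to compound 4 (0.04 log units; that floor lies within the scatter) and an at least 1.8-fold higher number from compound 2 to compound 4 (0.25 log units; that floor lies within the scatter). The step linking the two limits cannot be read, and among the compounds shown no group on this aromatic nitrogen has moved the read-out by a step shown to lie beyond the scatter.

As far as these compounds go, how far compound 4 lies past its limit stays open, so the true size of its steps is unknown. Also open, from the compounds shown here alone, is whether a group of another kind on this nitrogen, such as an amine, a carboxylic acid or a longer chain like phenethyl, would give a clearly lower number.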